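A few compounds are considered here, and "the series" means these few. Any claim that something is new, unique, unknown or untested is made for them only; others in the source may bear on it.

Compound 1 `O=C(NCC1(O)CCCC(F)(F)C1)c1cc(-c2ncc(F)cn2)ccc1Cl` stands lowest of the two numbers given in an in vitro ADME assay on microsomes from liver (Homo sapiens) for metabolic stability (a higher number here means faster removal of the compound, a lower number slower removal), where compound 1 gives 10 mL/min/kg. Compound 3 `O=C(NCC1(O)CCCCCC1)c1cc(-c2ccc(Cl)cn2)ccc1Cl` gives 52 mL/min/kg, a gap beyond the usual scatter. Compound 2 `O=C(NCC1(O)CCCC(F)(F)CC1)c1cc(-c2ncc(F)cn2)ccc1Cl` sits at the limit of < 8 mL/min/kg in this assay, at which 1 of the 3 values shown sits; in this assay compound 2 gives < 8 mL/min/kg, which is a limit of the assay and not a number. Compound 4 `O=C(NCC1(O)CCC(F)(F)CC1)c1cc(-c2ncc(F)cn2)ccc1Cl` differs from compound 1 in one place: 4,4-difluoro-1-hydroxycyclohexyl in place of 3,3-difluoro-1-hydroxycyclohexyl on a saturated chain carbon bound to an amide-type nitrogen. Going by the values given here, no measured pair shows what such a change does here, so the step of no change at the digits printed from compound 1 to compound 4 (within the scatter) is expected to be none beyond the scatter. Compound 4 is therefore estimated at 10 mL/min/kg in this assay, with a range from 6 mL/min/kg to 18 mL/min/kg.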

Compound 4, clearance: < 8.8 mL/min/kg
Compound 4: only a limit was reported; the forecaster's own chance of this, stated with the estimate: 30%; middle value at least 1.1-fold (0.05 log units) away from the limit.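

Swapping 3,3-difluoro-1-hydroxycyclohexyl for 4,4-difluoro-1-hydroxycyclohexyl gives in this assay an at least 1.1-fold lower number from compound 1 to compound 4 (0.05 log units; that floor lies within the scatter). Compound 4 reports a limit of the assay and not a number: the limit of < 8.8 mL/min/kg in this assay, at which 1 of the 4 values shown sits.

This first one-place comparison shows that the 4,4-difluoro ring gives no sign of faster removal than the 3,3-difluoro ring. The true size of the step cannot be read from a limit. The compounds shown also leave open whether an amine or a carboxylic acid on this ring, in place of the two fluorines, would keep removal as slow.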